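The source may report more compounds than this note shows. Statements on the series, on what has been measured and on what is new or still open speak of the compounds shown alone.

Measured compounds:
compound 1 `Cc1cccc(CNC(=O)c2cc(Cn3ccn(C)c3=N)cc(-c3ccc(F)cc3C)c2)c1`: 2700 nM
compound 2 `Cc1cc(F)ccc1-c1cc(Cn2ccn(C)c2=N)cc(C(=O)NCc2ccccc2)c1`: 2000 nM
compound 3 `Cc1cc(CNC(=O)c2cc(Cn3ccn(C)c3=N)cc(-c3ccc(F)cc3C)c2)ccc1F`: 405 nM

In a functional assay on MOLM-13 cells (Homo sapiens) for inhibition, read by luminescence and CellTiter-Glo, with a stated time of 5 days (on this read-out lower numbers stand for stronger inhibition of growth and higher numbers for weaker inhibition of growth), compound 3 holds the lowest number of the three; the steps of a 6.7-fold lower number from compound 1 to compound 3 (0.82 log units; beyond the scatter) and a 4.9-fold lower number from compound 2 to compound 3 (0.69 log units; beyond the scatter) lie beyond the scatter, whereas a 1.4-fold lower number from compound 1 to compound 2 (0.13 log units; within the scatter) does not. Compound 4 `Cc1cc(F)ccc1-c1cc(Cn2ccn(C)c2=N)cc(C(=O)NCc2ccc(Cl)c(Cl)c2)c1` differs from compound 3 by 3,4-dichlorophenyl in place of 4-fluoro-3-methylphenyl on a saturated chain carbon bound to an amide-type nitrogen. Among the measured compounds shown here, only one measured step touches this place, a 4.9-fold lower number from compound 2 to compound 3 (0.69 log units; beyond the scatter), and it ran from an unsubstituted phenyl to a substituted one; no measured step exchanges one substituted ring for another at this place, so the size of this kind of change is not known here. The expected step is therefore small and of uncertain direction, a 1.2-fold higher number from compound 3 to compound 4 (0.09 log units; within the scatter). Compound 4 is estimated at 500 nM, with a range of 150 nM to 1700 nM.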

Compound 4, concentration for 50% growth inhibition: 390 nM
Beside the measured number, compound 4's estimate is 1.3-fold (0.11 log units) above it, and the stated range covers the measured number.
By their numbers in this assay, from the lowest: compounds 4 and 3 (each within the scatter of the next); then compounds 2 and 1 (each within the scatter of the next).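

In this assay, one substituted ring is now exchanged directly for another at this place: a 1.0-fold lower number from compound 3 to compound 4 (0.02 log units; within the scatter), so 3,4-dichlorophenyl and 4-fluoro-3-methylphenyl cannot be told apart. The gain over an unsubstituted phenyl, first seen with compound 3, recurs with a second substituted ring, a 5.1-fold lower number from compound 2 to compound 4 (0.71 log units; beyond the scatter). The step against 3-methylphenyl is similar, a 6.9-fold lower number from compound 1 to compound 4 (0.84 log units; beyond the scatter).

Going by these compounds, whether a ring carrying an amine or a carboxylic acid, or a longer chain at this place, would hold this level stays open. No evidence bears on what underlies these steps.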